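Swapping one benzyl group on a sulfonyl chain

The source may hold more compounds than are shown below. What is called first, only, known or untested is meant among the compounds shown, and "the series" means these compounds.

Compound 1 `CC1OC(=O)c2cc(C#N)c(N3CCC(C(=O)NS(=O)(=O)Cc4ccccc4)C3)nc21`: > 300000 nM
Compound 2 `N#Cc1cc2c(nc1N1CCC(C(=O)NS(=O)(=O)Cc3cccc(F)c3)CC1)COC2=O`: 70500 nM

Both results come from a functional assay (Platelet, plasma) for inhibition, with Homo sapiens as the target; on this read-out higher numbers stand for weaker inhibition and lower numbers for stronger inhibition. For compound 1, > 300000 nM is a limit of the assay and not a number. Going by the values given here, compound 2, at 70500 nM, gives the only actual number so far, so there is no range of measured numbers in which to rank it. Among the compounds with values here, no step between two measured compounds is available as a guide either.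

Compound 3 `Cc1ccc(CS(=O)(=O)NC(=O)C2CCN(c3nc4c(cc3C#N)C(=O)OC4)CC2)cc1` keeps the shared core of compound 2 and alters one group: 4-methylphenyl in place of 3-fluorophenyl on a saturated chain carbon bound to a sulfonyl sulfur. In words, this is 4-methylphenyl in place of 3-fluorophenyl on a saturated chain carbon bound to a sulfonyl sulfur.

With so little to lean on, only a modest change is expected in this assay, possibly none beyond the usual scatter, with a slight lean towards weaker inhibition. The estimated step of a 1.1-fold higher number from compound 2 to compound 3 (0.05 log units; within the scatter) is therefore small. For compound 3 the estimate is 80000 nM, with an expected range of 30000 nM to 220000 nM.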

Compound 3, half-maximal inhibitory concentration: 4280 nM
Compound 3: middle estimate off by 19-fold (1.27 log units), on the high side, and the stated range ends above it.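

In this assay, putting 4-methylphenyl in place of 3-fluorophenyl on a saturated chain carbon bound to a sulfonyl sulfur gives a 16-fold lower number from compound 2 to compound 3 (1.22 log units; beyond the scatter), so the strength of inhibition responds sharply to the group at this position while the rest of the molecule stays the same. Both groups count 7 heavy atoms and one six-membered aromatic ring of carbon only, which means this large shift comes from a swap that leaves those counts unchanged. None of the information available accounts for the size of the step, and it offers no measured property that could explain it.

This one swap changes two things together, the kind of group on the ring and where the name places it, so the compounds shown cannot say which of the two matters, or whether both do. A 3-methylphenyl or a 4-fluorophenyl group would pull these two changes apart, and a plain phenyl group on the same core would show how much either group adds on its own.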